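The source may hold more compounds than are shown below. What is called first, only, known or untested is meant among the compounds shown, and "the series" means these compounds.

Compound 1, `O=C(O)CSC(CCCc1ccc(Cl)cc1)c1ccc(OCc2ccc3ccccc3n2)cc1`, gives 7 nM in a functional assay for inhibition of Polyunsaturated fatty acid 5-lipoxygenase (Homo sapiens); a lower number here means a stronger inhibitor, a higher number a weaker inhibitor.
Compound 2, `O=C(O)[C@@H](c1ccc(OCc2ccc3ccccc3n2)cc1)C1CCCC1`, gives 60 nM in this assay.
Compound 3, `CC/C(=N\OC(c1ccc(OCc2ccc3ccccc3n2)cc1)C1CCCCC1)C(=O)O`, gives 30 nM in this assay.

All three share the same core, a quinoline-methoxy-bearing phenyl ring carrying an acid-bearing side chain, and differ in how that side chain is built. Among the numbers measured so far, compound 3 and compound 2 lie within the usual scatter of each other, so no order between them can be read, while compound 1 gives a lower number by a gap beyond the scatter.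

Compound 4, `O=C(O)/C(=N/OC(c1ccc(OCc2ccc3ccccc3n2)cc1)C1CCCCC1)c1ccccc1`, is reached from compound 3 by one change: phenyl in place of ethyl on a carbon with a double bond to nitrogen. The acid, the oxime linkage and the cyclohexyl-bearing centre are all kept; only the group hanging on the oxime carbon is exchanged. For the measured compounds named here, no measured pair shows this exchange, so there is no step to lean on, and the expectation for compound 4 is a shift in this assay of about no change at the digits printed from compound 3 to compound 4 (within the scatter), that is, no clear change beyond the scatter. Compound 4 is therefore estimated at 30 nM, with a likely range from 10 nM to 100 nM.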

Compound 4, half-maximal inhibitory concentration: 31 nM
Estimate against measurement, compound 4: 1.0-fold (0.01 log units) below; measured number inside the range.
By their numbers in this assay, from the lowest: compound 1; then compounds 3, 4 and 2 (each within the scatter of the next).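

On the carbon with a double bond to nitrogen, phenyl in place of ethyl gives a 1.0-fold higher number from compound 3 to compound 4 (0.01 log units; within the scatter) in this assay. The earlier compounds shown here offered no pair differing in one place, whereas this pair shows that a six-membered aromatic ring can stand where the two-carbon ethyl stood with no readable shift in this assay. Nothing available explains why the two groups read alike.

Among the compounds shown, ethyl and phenyl are the only groups at this position, so it stays open whether a methyl, a longer chain such as hexyl, or a phenyl carrying an amine would read the same. From the compounds shown here alone, whether an amide could stand in place of the carboxylic acid also stays open.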